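A few compounds are considered here, and "the series" means these few. Any claim that something is new, unique, unknown or untested is made for them only; others in the source may bear on it.

Compound 1 `COc1ccc(-c2noc(-c3ccc(Cl)cc3)n2)cc1OC1CCCC1` was tested in a functional assay on MIA PaCa-2 cells (Homo sapiens) for antiproliferative activity, read by MTT assay, with a stated time of 24 h (a lower number here means a stronger inhibitor, a higher number a weaker inhibitor), and gave 740 nM. Among the measured compounds shown here, of the two compounds measured so far, compound 1 has the lowest number; the other, compound 2 `COc1ccc(-c2noc(Cc3c[nH]c4ccccc34)n2)cc1OC1CCCC1`, gave 9560 nM in this assay, a gap that lies beyond the usual scatter, so compound 1 is the stronger inhibitor of the pair.

Compound 3 `COc1ccc(-c2noc(-c3ccncc3)n2)cc1OC1CCCC1` has not yet been measured in this assay. It differs from compound 1 in one place: pyridin-4-yl in place of 4-chlorophenyl on an aromatic carbon. For the measured compounds named here, no pair of measured compounds differs by this kind of exchange, so there is no measured step to lean on. Going by the values given here, the only guidance is that compound 1 sets the strongest value seen, and that a swap of one aromatic ring for another of similar size is usually a smaller matter than the change that separates compound 1 from compound 2.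

On that basis compound 3 is expected to remain in the same broad range as compound 1, with a modest loss that may or may not exceed the scatter, a step of a 2.7-fold higher number from compound 1 to compound 3 (0.43 log units; beyond the scatter). The estimated value for compound 3 in this assay is 2000 nM, with a range from 600 nM to 8000 nM.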

Compound 3, half-maximal inhibitory concentration: 9330 nM
Beside the measured number, compound 3's estimate is 4.7-fold (0.67 log units) below it; measured number above the stated range.
By their numbers in this assay, from the lowest: compound 1; then compounds 3 and 2 (each within the scatter of the next).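

In this assay, putting pyridin-4-yl in place of 4-chlorophenyl on the aromatic carbon of the five-membered ring gives a 13-fold higher number from compound 1 to compound 3 (1.10 log units; beyond the scatter), a large step. Among the compounds shown here, this is the first measured change at this position, and it shows that the number can depend heavily on which six-membered aromatic ring sits there, even though the two rings are close in size. The ring of carbon only, with its chlorine, goes with the far lower number in this pair, while the ring with one hetero atom, which counts as a hydrogen-bond acceptor, goes with the higher one, and no measurement at hand explains the difference.

The exchange removes the chlorine and brings in the ring nitrogen in a single step, so the compounds shown cannot tell which of the two changes accounts for the shift. A plain phenyl ring would separate these two changes, and a 4-bromophenyl or 4-methylphenyl ring would show whether chlorine can be replaced by another group on the same ring without a similar rise.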